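The source may hold more compounds than are shown below. What is called first, only, known or untested is meant among the compounds shown, and "the series" means these compounds.

Of the compounds shown here, three have been measured in an assay on CHO cells for displacement of a labelled ligand from adenosine receptor A1 (Homo sapiens), read by scintillation counting, with a stated time of 60 min, tested at 10 uM; a higher number here means more inhibition at the concentration tested (going by the name of the read-out), a lower number less inhibition. Compound 1, `O=C(NCCCN1CCN(CCCNC(=O)c2cc3ccccc3oc2=O)CC1)c1cc2ccccc2oc1=O`, is a symmetric molecule carrying two coumarin-type units joined through a piperazine linker; in this assay compound 1 gives 9%. Compound 2, `CCC(CO)NC(=O)c1cc2cc(Br)ccc2oc1=N`, is a smaller amide with a bromine on its core, and compound 2 gives 20%. Compound 3, `COCCNC(=O)c1cc2cc(Cl)ccc2oc1=N`, has a chlorine on the same core and a 2-methoxyethyl group on the amide nitrogen; compound 3 gives 17%. The number for compound 3 sits between the other two, but its differences to compound 2 and to compound 1 are both within the usual scatter, so the three compounds cannot be ranked against one another.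

Compound 4, `CCC(CO)NC(=O)c1cc2cc(Cl)ccc2oc1=N`, differs from compound 3 in one place: 1-(hydroxymethyl)propyl in place of 2-methoxyethyl on an amide-type nitrogen. Among the compounds with values here, no measured pair shows the effect of this change, but compound 2 already carries the entering group, with bromine instead of chlorine, and compound 2 gives 20%, close to compound 3. The step of a number 2 percentage points higher from compound 3 to compound 4 (within the scatter) is therefore expected to be small and to stay within the scatter. Compound 4 is expected to give 19%, with a likely range from 8% to 30%.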

Compound 4, a percentage reported as inhibition, at one concentration (the size of the read-out at that concentration, not a potency): 7%
For compound 4 the middle estimate is 12 percentage points above the measured one; measured number outside the range, below it.
By their numbers in this assay, from the lowest: compounds 4, 1, 3 and 2 (each within the scatter of the next, the first and the last beyond it).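

In this assay, within the data shown here, placing 1-(hydroxymethyl)propyl instead of 2-methoxyethyl on the amide-type nitrogen gives a number 10 percentage points lower from compound 3 to compound 4 (within the scatter) as the first direct reading at this position, so this change cannot be told apart from the ordinary spread of repeated measurements. Among these compounds, the new compound also gives the first direct reading of the halogen: with the same nitrogen group on both compounds, chloro in place of bromo on the aromatic carbon gives a number 13 percentage points lower from compound 2 to compound 4 (beyond the scatter) and is the only step here that clears the scatter, though it is modest, so a bromo compound is not a safe stand-in for its chloro partner in this assay. No accompanying measurement bears on why this halogen step appears, so it stands as an observation only.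

From the compounds shown here alone, whether the chloro-for-bromo step repeats with 2-methoxyethyl on the nitrogen remains open, as does the outcome of a fluoro or methyl group on that aromatic carbon. Among the compounds shown here, also open is what a longer chain, or a chain ending in an amine or a carboxylic acid, would do on the amide-type nitrogen, and these single-concentration readings give no potency for any compound.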